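The source may hold more compounds than are shown below. What is called first, only, known or untested is meant among the compounds shown, and "the series" means these compounds.

In a functional assay on the whole organism (strain Wistar) for inhibition, with Rattus norvegicus as the target, read by paw edema, with stated times of 30 min and 5 h, at a dose of 0.05 mmol/kg by the oral route (on this read-out lower numbers stand for less inhibition and higher numbers for more inhibition at the one dose given (going by the name of the read-out)), compound 1 `Cc1ccc(C2=NN(c3ccc(S(C)(=O)=O)cc3)C(=O)CC2)cc1` gives 60.5%, compound 2 `Cc1cc(C2=NN(c3ccc(S(C)(=O)=O)cc3)C(=O)CC2)ccc1O` gives 60.5%, and compound 3 `Cc1cc(O)ccc1C1=NN(c2ccc(S(C)(=O)=O)cc2)C(=O)CC1` gives 52.6%. Compound 3 has the lowest of the three numbers, yet the gaps to it, a number 7.9 percentage points lower from compound 1 to compound 3 (within the scatter) and a number 7.9 percentage points lower from compound 2 to compound 3 (within the scatter), both lie within the scatter, as does no change at the digits printed from compound 1 to compound 2 (within the scatter). Compound 4 `CCc1ccc(C2=NN(c3ccc(S(C)(=O)=O)cc3)C(=O)CC2)cc1` differs from compound 3 by 4-ethylphenyl in place of 4-hydroxy-2-methylphenyl on a carbon with a double bond to nitrogen. Among the compounds with values here, the most telling comparison is the one in which compound 1 carried the 4-methylphenyl, since the 4-ethylphenyl of compound 4 likewise lacks the hydroxy group; that step was small and within the scatter. Compound 4 is therefore expected to sit near compound 1, with an expected step of a number 7.4 percentage points higher from compound 3 to compound 4 (within the scatter), and its estimated value in this assay is 60%, between 46% and 72%.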

Compound 4, a percentage reported as inhibition, in the whole organism at one dose (the size of the read-out at that dose, not a potency): 65.7%
Estimate against measurement, compound 4: 5.7 percentage points below, within the range that was stated.
By their numbers in this assay, from the lowest: compounds 3, 1, 2 and 4 (each within the scatter of the next, the first and the last beyond it).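

In this assay, within the data shown here, the 4-ethylphenyl gives the first step at this position that lies beyond the scatter (a number 13.1 percentage points higher from compound 3 to compound 4 (beyond the scatter)), and that step is set against the 4-hydroxy-2-methylphenyl alone. Against the 4-hydroxy-3-methylphenyl (a number 5.2 percentage points higher from compound 2 to compound 4 (within the scatter)) and against the 4-methylphenyl (a number 5.2 percentage points higher from compound 1 to compound 4 (within the scatter)), the steps stay within the scatter, so the extra methyl on the chain shows no clear effect. Nothing available explains these steps. Going by these compounds, whether a longer chain such as propyl, or an amine, would fit here remains open.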